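Nitro in place of chloro: expected number for compound 4

The compounds below may be only part of what the source reports. "The series", "measured", "known", "first", "only" and "open" are said of these compounds alone.

Compound 3 `CC1=CC[C@H](C(C)(C)NC(=S)N/N=C/c2ccccc2Cl)CC1` gives 5600 nM in a functional assay on K562 cells (Homo sapiens) for inhibition, read by sulforhodamine B assay, with a stated time of 48 h (on this read-out lower numbers stand for stronger inhibition of growth and higher numbers for weaker inhibition of growth), and sits second highest of the three numbers; compound 1 `CC1=CC[C@H](C(C)(C)NC(=S)N/N=C/c2ccccc2)CC1` gives 6300 nM, within the scatter of compound 3, while compound 2 `CC1=CC[C@H](C(C)(C)NC(=S)N/N=C/c2ccccc2O)CC1` gives 800 nM, the furthest away. For the measured compounds named here, the step of a 7.0-fold higher number from compound 2 to compound 3 (0.85 log units; beyond the scatter) is the only one touching compound 3 that lies beyond the scatter; the step of a 1.1-fold lower number from compound 1 to compound 3 (0.05 log units; within the scatter) stays within it, and the step of a 7.9-fold lower number from compound 1 to compound 2 (0.90 log units; beyond the scatter) is modest. Compound 4 `CC1=CC[C@H](C(C)(C)NC(=S)N/N=C/c2ccccc2[N+](=O)[O-])CC1` differs from compound 3 by nitro in place of chloro on an aromatic carbon. Going by the values given here, no measured step introduces a nitro group, so the bearing is indirect: compound 1 and compound 3 lie within the scatter of each other in this assay, and only compound 2 stands apart. For compound 4 the expected step is a 1.1-fold lower number from compound 3 to compound 4 (0.05 log units; within the scatter), within the scatter. Compound 4 is therefore estimated at 5000 nM in this assay, with a range of 1500 nM to 16000 nM.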

Compound 4, concentration for 50% growth inhibition: 300 nM
Beside the measured number, compound 4's estimate is 17-fold (1.22 log units) above it; measured number below the stated range.
By their numbers in this assay, from the lowest: compound 4; then compound 2; then compounds 3 and 1 (each within the scatter of the next).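

In this assay, for the compounds shown here, a single exchange at this place on the aromatic ring now gives a large drop, a 19-fold lower number from compound 3 to compound 4 (1.27 log units; beyond the scatter) and a 21-fold lower number from compound 1 to compound 4 (1.32 log units; beyond the scatter), so hydroxy is no longer the only group that separates from hydrogen. Nitro also goes further than hydroxy, a 2.7-fold lower number from compound 2 to compound 4 (0.43 log units; beyond the scatter), while chloro remains the compound that goes against any reading that substitution here lowers the number. Nothing measured here accounts for the gap between nitro and chloro. As far as these compounds go, whether an amine or a carboxylic acid at this place would group with nitro and hydroxy or with chloro and hydrogen remains open.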